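Amine side-chain variation in a serotonin receptor binding series

This account rests on a few compounds, and the source may have more. Where it says the series, first, only, none or still open, it means among the compounds named here.

Compound 1, `CCCN(CCC)Cc1ccc(Cl)c(-c2ccccc2OC)c1`, in an assay on isolated protein for binding affinity to 5-hydroxytryptamine receptor 3A (Homo sapiens) (on this read-out higher numbers stand for weaker inhibition and lower numbers for stronger inhibition), gives > 10000 nM, a limit of the assay and not a number.
Compound 2, `COc1ccccc1-c1cc(C2CCNC2)ccc1Cl`, in this assay gives 590 nM.
Compound 3, `CCNCc1ccc(Cl)c(-c2ccccc2OC)c1`, in this assay gives > 10000 nM, a limit of the assay and not a number.

Compound 3 stands only at a limit; it shares that position with one other value shown, namely (the limit of > 10000 nM in this assay, at which 2 of the 3 values shown sit). Among the measured compounds shown here, its only readable step is an at least 16-fold higher number from compound 2 to compound 3 (1.22 log units; beyond the scatter), a large loss. The step that the two limits leave unreadable from compound 1 to compound 3 cannot be sized because both ends sit at the limit of > 10000 nM in this assay, at which 2 of the 3 values shown sit.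

Compound 4, `CCCCNCc1ccc(Cl)c(-c2ccccc2OC)c1`, differs from compound 3 by ethyl in place of hydrogen on a saturated chain carbon, two bonds along the chain from an amine nitrogen. The step from compound 1 to compound 3 is the only one that touches the same amine chain, and it is unreadable; the step from compound 2 to compound 3 concerns a different change. Nothing shown therefore indicates a move away from the limit, and compound 4 is expected to remain there, with an estimated step that the limit leaves unreadable from compound 3 to compound 4 that is not beyond the scatter. Compound 4 is estimated at 15000 nM in this assay, in a range of 4000 nM to 60000 nM.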

Compound 4, inhibition constant: > 10000 nM
Compound 4 was reported as a limit; the forecaster's own chance of this, stated with the estimate: 80%; the middle value lies beyond the limit too.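

In this assay compound 4 gives > 10000 nM, a limit of the assay and not a number. Butylamino in place of ethylamino thus leaves this side chain at the limit, as it stands for the dipropylamino of compound 1 and the ethylamino of compound 3: the limit of > 10000 nM in this assay, at which 3 of the 4 values shown sit.

Among the compounds shown here, compound 2, with pyrrolidin-3-yl, remains the only compound here with a readable value, and (butylamino)methyl in its place gives an at least 16-fold higher number from compound 2 to compound 4 (1.22 log units; beyond the scatter); the steps among compound 1, compound 3 and compound 4 cannot be read, so any effect of chain length stays hidden.

Open, going by these compounds, is whether an aminomethyl or (methylamino)methyl group, or a piperidin-3-yl ring, would give a readable value. Also open, on these data alone, is how far compound 1, compound 3 and compound 4 lie beyond the limit, and whether they differ from one another.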